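The source may hold more compounds than are shown below. What is called first, only, known or untested is meant among the compounds shown, and "the series" means these compounds.

In an ADME assay on Vero cells (Chlorocebus sabaeus) for cytotoxicity, read by MTT assay (on this read-out higher numbers stand for lower toxicity in this test and lower numbers for higher toxicity in this test), compound 1, `CCCCC#Cc1c[nH]c(=O)[nH]c1=O`, gives 253000 nM. Among the three numbers measured so far this is the highest, yet compound 3, `O=c1[nH]cc(C#CC(O)c2ccccc2)c(=O)[nH]1`, gives 242000 nM in this assay, a value that lies within the usual scatter of the value of compound 1, so the two cannot be told apart. Compound 2, `CCCCCCC#Cc1cn([C@@H]2O[C@H](CO)[C@@H](O)[C@H]2O)c(=O)[nH]c1=O`, gives 111000 nM in this assay, and that number lies beyond the scatter below the value of compound 1.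

The compound still to be measured is compound 4, `O=c1[nH]cc(C#CC2CC2)c(=O)[nH]1`. Set against compound 1 its structure differs in a single place: cyclopropyl in place of butyl on a triple-bonded carbon. Within the data shown here, no pair of measured compounds shows this particular change, so there is no step on which to lean, and the expectation has to rest on the three values seen so far, which cluster in a fairly narrow band. For compound 4 the expected step is a 1.1-fold lower number from compound 1 to compound 4 (0.02 log units; within the scatter), estimated to be none beyond the scatter. The value of compound 4 in this assay is therefore estimated at 240000 nM, with a range from 110000 nM to 500000 nM.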

Compound 4, half-maximal cytotoxic concentration: 252000 nM
Compound 4: the middle estimate sits 1.1-fold (0.02 log units) below what was measured; the range from low to high includes it.
By their numbers in this assay, from the lowest: compound 2; then compounds 3, 4 and 1 (each within the scatter of the next).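

In this assay, among these compounds, cyclopropyl in place of butyl on a triple-bonded carbon gives a 1.0-fold lower number from compound 1 to compound 4 (0.00 log units; within the scatter), the only step at this position that can be read directly. The two numbers cannot be told apart, so for this one pair, three carbons held in a three-membered ring serve as well as the four carbons of the open butyl chain in keeping the reading in this test where compound 1 has it: the chain shape and the extra carbon make no visible difference here. No measured information explains why the swap leaves the reading indistinguishable, so this stands as an observation without a stated cause.

Butyl and cyclopropyl are both made of carbon alone and neither carries a hydrogen-bond donor or acceptor, so the compounds shown leave open how this position would read with an amine, a carboxylic acid or a much longer chain on the shared core. One pair also cannot tell whether the same swap would read the same way on a different core, so nothing here extends beyond compound 1 and compound 4.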